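A few compounds are considered here, and "the series" means these few. Any claim that something is new, unique, unknown or untested is made for them only; others in the source may bear on it.

In a functional assay on HeLa cells (Homo sapiens) for inhibition, read by CCK-8 assay, with a stated time of 72 h (a higher number here means a weaker inhibitor, a lower number a stronger inhibitor), compound 2 (`O=C(/C=C/c1cccnc1)NCCCCCCc1cccc(S(=O)(=O)Nc2ccccc2)c1`) reads 30.4 nM and stands second highest of three numbers, with compound 1 (`O=C(/C=C/c1cccnc1)NCCCCc1ccc(S(=O)(=O)Nc2ccccc2)cc1`) higher at 184 nM and compound 3 (`Cc1ccccc1NS(=O)(=O)c1cccc(CCCCCCNC(=O)/C=C/c2cccnc2)c1`) lower at 2.34 nM in the same read-out. Compound 4 (`O=C(/C=C/c1cccnc1)NCCCCCCc1cccc(S(=O)(=O)Nc2ccc(F)cc2)c1`) differs from compound 2 by fluoro in place of hydrogen on an aromatic carbon and carries fluoro in place of hydrogen on an aromatic carbon, para to a large group. Within the data shown here, the only measured step on this part of the structure (a 13-fold lower number from compound 2 to compound 3 (1.11 log units; beyond the scatter)) was large, but it brings methyl, so it bears only loosely. Among the measured compounds shown here, no fluoro step has been measured. A small move to a lower number in this assay is expected, possibly none beyond the scatter. The estimated step is (a 1.5-fold lower number from compound 2 to compound 4 (0.18 log units; within the scatter)) and remains tentative. For compound 4 the expected value is 20 nM (estimated range 6 nM to 60 nM).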

Compound 4, half-maximal inhibitory concentration: 99.9 nM
For compound 4 the middle estimate is 5.0-fold (0.70 log units) below the measured one, and the stated range ends below it.
By their numbers in this assay, from the lowest: compound 3; then compound 2; then compounds 4 and 1 (each within the scatter of the next).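

Substitution on the anilino phenyl ring does not push this assay in a single direction: fluoro in place of hydrogen, para to a large group, gives a 3.3-fold higher number from compound 2 to compound 4 (0.52 log units; beyond the scatter) while methyl on the same ring gave a 13-fold lower number from compound 2 to compound 3 (1.11 log units; beyond the scatter) in the opposite direction. Replacing 2-methylphenyl with 4-fluorophenyl on the sulfonamide nitrogen gives a 43-fold higher number from compound 3 to compound 4 (1.63 log units; beyond the scatter) and so separates the two substituted rings by more than either step from compound 2 alone. No evidence is available to explain this difference.

On these data alone, whether chloro, methoxy or an amine on this ring would follow the fluoro step or the methyl step remains open. So does whether the fluoro step would carry over to the shorter chain of compound 1.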